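The compounds below may be only part of what the source reports. "The series", "measured", "known", "first", "only" and "open" are said of these compounds alone.

Measured so far in an assay on isolated protein for inhibition of Rho-associated protein kinase 2 (Homo sapiens), read by scintillation counting, radiometric assay and 33P incorporation, with a stated time of 40 min, in the presence of a further agent that is not named here; a lower number here means a stronger inhibitor, a higher number a weaker inhibitor:
compound 1 `CCOc1ccc(C(=O)Nc2cccc(NC(=O)COc3ccc4c(=O)ccoc4c3)c2)cc1` gives 9 nM
compound 2 `CC(C)(C)c1ccc(S(=O)(=O)Nc2cccc(NC(=O)COc3ccc4c(=O)ccoc4c3)c2)cc1` gives 899 nM
compound 3 `O=C(COc1ccc2c(=O)ccoc2c1)Nc1cccc(NS(=O)(=O)c2ccc(OC(F)(F)F)cc2)c1` gives 1280 nM

Compound 1 has the lowest number of the three; compound 2 is nearest to it and compound 3 furthest, and both gaps lie beyond the scatter. Among the compounds with values here, the one step between measured compounds that differ in a single place is a 1.4-fold higher number from compound 2 to compound 3 (0.15 log units; within the scatter). Compounds 2 and 3 share a linkage to their aryl group that compound 1 does not have, so that step does not bear directly on a change at the carbonyl of compound 1; it shows only that, in that pair, an exchange of the group on the aromatic carbon moved the number little.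

Compound 4 `Nc1cccc(C(=O)Nc2cccc(NC(=O)COc3ccc4c(=O)ccoc4c3)c2)c1` has not yet been measured in this assay. It differs from compound 1 by 3-aminophenyl in place of 4-ethoxyphenyl on a carbonyl carbon. The carbonyl amide linkage of compound 1 is kept. Within the data shown here, no measured pair isolates a change of the aryl group on this carbonyl carbon, so the expectation rests on the change itself and on compound 1 as the starting point. The step from compound 1 is expected to be a 2.8-fold higher number from compound 1 to compound 4 (0.44 log units; beyond the scatter), a modest loss or none beyond the scatter. Compound 4 is estimated at 25 nM, with a range from 6 nM to 100 nM.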

Compound 4, half-maximal inhibitory concentration: 58 nM
For compound 4 the middle estimate is 2.3-fold (0.37 log units) below the measured one; measured number inside the range.
By their numbers in this assay, from the lowest: compound 1; then compound 4; then compounds 2 and 3 (each within the scatter of the next).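

In this assay, within the data shown here, the step of a 6.4-fold higher number from compound 1 to compound 4 (0.81 log units; beyond the scatter) is the first single change read on the aryl group of the carbonyl amide linkage, and it shows that this position responds to the exchange of that group. The response stays limited: compound 4 still gives 58 nM, so a potent number here does not depend on keeping 4-ethoxyphenyl, and 3-aminophenyl, which brings a hydrogen-bond donor that the group it replaces lacks, is also compatible with one. The change removes the ethoxy chain, introduces an amine and alters the position of the substituent in a single step, and no measurement at hand bears on which of these accounts for the shift.

Still open, as far as these compounds go, is whether the loss follows the arrival of the amine or the departure of the ethoxy chain; an unsubstituted phenyl, a longer alkoxy chain or a carboxylic acid on this aryl group would help separate those readings. Also open is how the carbonyl and sulfonyl linkages compare, as no compounds shown carry the same aryl group on both.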